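Cyanoguanidine for allyl thiourea on the pyridazinone side chain

The source may report more compounds than this note shows. Statements on the series, on what has been measured and on what is new or still open speak of the compounds shown alone.

Compound 1, `C/N=C(/NC#N)NCCCn1nc(-c2ccccc2)ccc1=O`, in a functional assay on the whole organism (stomach) with Rattus norvegicus as the target (a higher number here means that more compound is needed for the effect, a lower number that less compound is needed), gives > 100 mg/kg, a limit of the assay.
Compound 2, `C/N=C(\S)NCCCCCn1nc(-c2ccccc2)ccc1=O`, gives 35.3 mg/kg in this assay.
Compound 3, `C=CCNC(=S)NCCCCn1nc(-c2ccccc2)ccc1=O`, gives > 100 mg/kg in this assay, again a limit.

Compound 3 thus stands at the limit, where two of the three values sit, as the limit of > 100 mg/kg in this assay, at which 2 of the 3 values shown sit, records. The measured steps show an at least 2.8-fold lower number from compound 1 to compound 2 (0.45 log units; beyond the scatter) and an at least 2.8-fold higher number from compound 2 to compound 3 (0.45 log units; beyond the scatter), while a step that the two limits leave unreadable from compound 1 to compound 3 is not readable from the two limits.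

Compound 4, `N#CNC(=N)NCCCCn1nc(-c2ccccc2)ccc1=O`, differs from compound 3 by a group of 5 heavy atoms (2 carbon, 3 nitrogen; no ring) in place of a group of 6 heavy atoms (4 carbon, 1 nitrogen, 1 sulfur; no ring), on an amine nitrogen. Among the measured compounds shown here, this change brings compound 4 close to compound 1, which carries a related cyanoguanidine and gives only a limit, and moves it away from compound 2, the one compound with a read number. For the measured compounds named here, no measured step bears directly on it. Compound 4 is therefore expected to remain near the limit, an expected step that the limit leaves unreadable from compound 3 to compound 4. The estimate for compound 4 is 110 mg/kg, with a range from 40 mg/kg to 300 mg/kg, and it is likely that this assay again reports only a limit.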

Compound 4, dose for half-maximal effect: 77.2 mg/kg
For compound 4 the middle estimate is 1.4-fold (0.15 log units) above the measured one; the measured number falls inside the stated range.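

With a cyanoguanidine on the amine nitrogen, compound 4 gives a read number in this assay, but its floors against the two compounds at the limit are small: an at least 1.2-fold lower number from compound 3 to compound 4 (0.11 log units; that floor lies within the scatter), and an at least 1.2-fold lower number from compound 1 to compound 4 (0.11 log units; that floor lies within the scatter). The comparison with the one other read number gives a step of definite size, a 2.2-fold higher number from compound 2 to compound 4 (0.34 log units; beyond the scatter), so compound 2 remains the most potent of the four compounds shown, and the cyanoguanidine on this four-step chain does not match its end group. Against compounds 1 and 3, only floors can be given: the limit of > 100 mg/kg in this assay, at which 2 of the 4 values shown sit.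

Compounds 2 and 4 differ in chain length as well as in the end group, so the two contributions stay unseparated. From the compounds shown here alone, how a urea in place of the cyanoguanidine, or a longer chain carrying the cyanoguanidine, would read in this assay remains open.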